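The source may report more compounds than this note shows. Statements on the series, on what has been measured and on what is new or still open speak of the compounds shown alone.

Measured compounds:
Compound 1, `CCC(C(=O)O)S(=O)(=O)c1ccc(OCc2cccc(-c3c(C)cc(OC)cc3C)c2)cc1`: in a functional assay on CHO cells for agonist activity at Free fatty acid receptor 1 (Homo sapiens), read by FLIPR and calcium flux (a lower number here means that less compound is needed, a higher number that more compound is needed for the effect), compound 1 gives > 1000 nM, which is a limit of the assay and not a number.
Compound 2, `Cc1nc(-c2ccccc2)sc1COc1ccc(S(=O)(=O)CC(=O)O)cc1`: in this assay compound 2 gives 331 nM.

For the measured compounds named here, compound 2 therefore holds the only real number in this set. The other value recorded belongs to compound 1 and sits at the limit (the limit of > 1000 nM in this assay, at which 1 of the 2 values shown sits), so compound 1 and compound 2 cannot be compared beyond saying that compound 2 was quantified and compound 1 was not.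

Compound 3, `Cc1cccc(-c2nc(C)c(COc3ccc(S(=O)(=O)CC(=O)O)cc3)s2)c1`, is built from compound 2 by a single change, (methyl in place of hydrogen on an aromatic carbon), that is, methyl in place of hydrogen on an aromatic carbon, meta to a large group on the six-membered carbon ring. Going by the values given here, no pair of measured compounds shows this kind of step, so there is nothing here to calibrate it against. A change this small, one added carbon and no new donor or acceptor, is expected to move the result little in this assay, likely no further than the usual scatter of repeated runs, with no preferred direction.

Compound 3 is therefore estimated at 300 nM, with a plausible range from 100 nM to 1000 nM, meaning an expected step of a 1.1-fold lower number from compound 2 to compound 3 (0.04 log units; within the scatter).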

Compound 3, half-maximal effective concentration: 214 nM
Compound 3: the middle estimate sits 1.4-fold (0.15 log units) above what was measured; the measured number falls inside the stated range.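

Placing methyl where hydrogen stood, which turns phenyl into 3-methylphenyl, gives a 1.5-fold lower number from compound 2 to compound 3 (0.19 log units; within the scatter) in this assay. For the compounds shown here, this is the first reading of this position, on a six-membered aromatic ring of carbon only and meta to a large group, and it shows that one added carbon here leaves the result indistinguishable from that of the unsubstituted ring, so the methyl is tolerated but cannot be counted as a gain. Nothing measured in this set offers a reason for the size of this step.

A single methyl says little about what else this position would accept, so a methoxy group, a chlorine atom, a trifluoromethyl group or an amine could each behave differently, and a longer chain such as ethyl or propyl would show whether more carbon is also tolerated. Going by these compounds, it also remains open whether the same methyl would give a similar result elsewhere on this ring, or on a core carrying a different acid side chain.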